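Shifting the Methoxyphenyl Group from Compound 2 to Compound 4

The source may report more compounds than this note shows. Statements on the series, on what has been measured and on what is new or still open speak of the compounds shown alone.

Compound 1 `O=C1COc2ccc(-c3ccc(O)cc3)cc2N1`: > 40000 nM in a functional assay on A549 cells (Homo sapiens) for antiproliferative activity, read by MTT assay, with a stated time of 72 h; a higher number here means a weaker inhibitor, a lower number a stronger inhibitor
Compound 2 `COc1ccc(N2C(=O)COc3ccc(-c4ccc(O)cc4)cc32)cc1`: > 40000 nM
Compound 3 `O=C1COc2ccc(-c3cnc(Cl)c(NS(=O)(=O)c4ccc(F)cc4)c3)cc2N1C1CCCCC1`: 37900 nM in this assay.

Compound 1 has only a limit of the assay as its value, not a number. For compound 2 the value is likewise only a limit. Compound 3 gives a real number, close to that limit. Compound 2 therefore stands at the limit (the limit of > 40000 nM in this assay, at which 2 of the 3 values shown sit), with no number of its own. The step that the two limits leave unreadable from compound 1 to compound 2 runs between two limits and cannot be read.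

Compound 4 `COc1cccc(N2C(=O)COc3ccc(-c4ccc(O)cc4)cc32)c1` differs from compound 2 by 3-methoxyphenyl in place of 4-methoxyphenyl on an amide-type nitrogen in a ring. Among the measured compounds shown here, no measured step alters this methoxyphenyl group, so none bears directly on the move. With compound 2 at the limit (the limit of > 40000 nM in this assay, at which 2 of the 3 values shown sit), compound 4 is expected to show no step beyond the scatter in this assay, estimated as a number no higher from compound 2 to compound 4 (the limit leaves the size open). Compound 4 is estimated at 40000 nM, between 15000 nM and 100000 nM, most likely reported only as a limit.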

Compound 4, half-maximal inhibitory concentration: > 40000 nM
Compound 4 ended at the assay's limit (the forecaster's own chance of this, stated with the estimate: 75%); the middle value lies on the limit itself.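

Compound 1, compound 2 and compound 4 all stand at a limit, not a number, so no step among them can be read: the limit of > 40000 nM in this assay, at which 3 of the 4 values shown sit.

From the compounds shown here alone, whether 3-methoxyphenyl and 4-methoxyphenyl differ at all in this assay stays open.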